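The source may report more compounds than this note shows. Statements on the series, on what has been measured and on what is new or still open speak of the compounds shown alone.

In an ADME assay on the whole organism (plasma, strain Sprague-Dawley) for pharmacokinetics, with Rattus norvegicus as the target, at a dose of 2 mg/kg by the oral route (a higher number here means more compound in the circulation at the dose given, a lower number less compound in the circulation), compound 2 `Cc1cnc(C(=O)NC2CC2)cc1-c1cc2cnnc(-c3ccccc3Cl)c2n(C)c1=O` stands highest of the two numbers, at 1460 ng.h/mL; compound 1 `Cc1cnc(C(=O)NC2CC2)cc1-c1cc2cnnc(-c3ccccc3C)c2n(C)c1=O` gives 543 ng.h/mL. For the measured compounds named here, the one measured step, a 2.7-fold higher number from compound 1 to compound 2 (0.43 log units; beyond the scatter), concerns the same aromatic carbon that is changed in compound 3 `Cc1cnc(C(=O)NC2CC2)cc1-c1cc2cnnc(-c3ccc(F)cc3C)c2n(C)c1=O`, where (4-fluoro-2-methylphenyl in place of 2-chlorophenyl on an aromatic carbon). Going by the values given here, that step bears on the return of a methyl group, which on its own would point the other way; the added fluorine has no measured counterpart here. The expected outcome for compound 3 is therefore a modest decrease, a 2.1-fold lower number from compound 2 to compound 3 (0.32 log units; beyond the scatter), giving an estimate of 700 ng.h/mL, in the range 300 ng.h/mL to 1600 ng.h/mL.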

Compound 3, area under the concentration-time curve: 2410 ng.h/mL
The estimate for compound 3 lay 3.4-fold (0.54 log units) below the measured number; the measured number lies above the stated range.
By their numbers in this assay, from the lowest: compound 1; then compounds 2 and 3 (each within the scatter of the next).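

In this assay, fluoro in place of hydrogen with the methyl group kept gives a 4.4-fold higher number from compound 1 to compound 3 (0.65 log units; beyond the scatter), so the methyl group alone does not fix the number of compound 1. Exchanging 2-chlorophenyl for 4-fluoro-2-methylphenyl gives a 1.7-fold higher number from compound 2 to compound 3 (0.22 log units; within the scatter), so these two rings cannot be told apart here. No measurement at hand explains either step. On these data alone, it remains open whether fluoro would have the same effect on the 2-chlorophenyl ring, and whether a methoxy group or an amine in its place would keep the number.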